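Replacing piperidin-1-yl in compound 3

The source may hold more compounds than are shown below. What is called first, only, known or untested is meant among the compounds shown, and "the series" means these compounds.

In a functional assay on A20 cells (Mus musculus) for inhibition, with stated times of 1 h, 16 h and 24 h (a higher number here means a weaker inhibitor, a lower number a stronger inhibitor), compound 1 (`N#CCNC(=O)[C@@H]1CC(F)(F)C[C@H]1C(=O)N1CCOCC1`) gives 925 nM, compound 2 (`N#CCNC(=O)[C@@H]1C[C@@H](S(=O)(=O)c2ccccc2Cl)C[C@H]1C(=O)N1CCOCC1`) gives 3 nM and compound 3 (`N#CC1(NC(=O)[C@@H]2C[C@@H](S(=O)(=O)c3ccccc3)C[C@H]2C(=O)N2CCCCC2)CC1`) gives 5 nM. Compound 3 cannot be told apart from compound 2 within the scatter, while compound 1 stands far above both in number. Compound 4 (`N#CC1(NC(=O)[C@@H]2C[C@@H](S(=O)(=O)c3ccccc3)C[C@H]2C(=O)Nc2ccc(F)cc2)CC1`) carries (4-fluorophenyl)amino in place of piperidin-1-yl on a carbonyl carbon. For the measured compounds named here, no measured pair shows this change alone, so any forecast in this assay remains uncertain. The expected step of a 1.6-fold higher number from compound 3 to compound 4 (0.20 log units; within the scatter) is slight, towards a higher number, and is not expected to exceed the scatter. Compound 4 is estimated at 8 nM, with an expected range of 2 nM to 40 nM.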

Compound 4, half-maximal inhibitory concentration: 391 nM
The estimate for compound 4 lay 49-fold (1.69 log units) below the measured number; the whole stated range lies below it.
By their numbers in this assay, from the lowest: compounds 2 and 3 (each within the scatter of the next); then compound 4; then compound 1.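

For the compounds shown here, the first single-place comparison at this carbonyl carbon shows that the position is far from indifferent: in this assay, the change gives a 78-fold higher number from compound 3 to compound 4 (1.89 log units; beyond the scatter). The change replaces a saturated ring without a hydrogen-bond donor by an aromatic ring on an amino group that carries one, and this single pair cannot separate those differences. Nothing available accounts for the step.

From the compounds shown here alone, it remains open how this position would respond to cyclohexylamino, phenylamino or methyl(4-fluorophenyl)amino, which would separate the contributions of the aromatic ring, fluorine and amide hydrogen.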